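The compounds below may be only part of what the source reports. "The series", "measured", "known", "first", "only" and "open" are said of these compounds alone.

Compound 3, `CCC(=O)OC[C@H]1[C@H]2CC[C@@H](C)[C@]1(C)CC/C(C)=C/CC[C@@]1(C)O[C@@H]1[C@@H]2O`, stands at the weak end of this small set: in an assay (Oryctolagus cuniculus) for inhibition of platelet-activating factor receptor (Cavia porcellus) (on this read-out lower numbers stand for stronger inhibition and higher numbers for weaker inhibition), compound 3 gives 340 nM, the highest of the three numbers. Its nearest neighbour is compound 2, `CC(=O)OC[C@H]1[C@H]2CC[C@@H](C)[C@]1(C)CC/C(C)=C/CC[C@@]1(C)O[C@@H]1[C@@H]2O`, which in this assay gives 80 nM; the furthest is compound 1, `COC(=O)OC[C@H]1[C@H]2CC[C@@H](C)[C@]1(C)CC/C(C)=C/CC[C@@]1(C)O[C@@H]1C2=O`, which in this assay gives 26 nM.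

The next compound, compound 4, `COC(=O)OC[C@H]1[C@H]2CC[C@@H](C)[C@]1(C)CC/C(C)=C/CC[C@@]1(C)O[C@@H]1[C@@H]2O`, differs from compound 3 in one place: methoxy in place of ethyl on a carbonyl carbon. Going by the values given here, only one measured step touches this part of the molecule, the change a 4.3-fold higher number from compound 2 to compound 3 (0.63 log units; beyond the scatter), which shows that lengthening the acyl chain by one carbon costs potency. Compound 1 carries the same methoxycarbonyl group as compound 4, but it also differs from compound 4 elsewhere, so its value can only hint that this group sits well with strong inhibition.

Reversing the direction of the acetate-to-propanoate step, compound 4 is expected to move back toward compound 2, a step of a 4.9-fold lower number from compound 3 to compound 4 (0.69 log units; beyond the scatter), with an estimate of 70 nM and a range from 25 nM to 200 nM.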

Compound 4, half-maximal inhibitory concentration: 130 nM
The estimate for compound 4 lay 1.9-fold (0.27 log units) below the measured number, and the stated range covers the measured number.
By their numbers in this assay, from the lowest: compound 1; then compounds 2 and 4 (each within the scatter of the next); then compound 3.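

Replacing ethyl with methoxy on this carbonyl carbon brings the number back down in this assay, a change of a 2.6-fold lower number from compound 3 to compound 4 (0.42 log units; beyond the scatter) and one that lies beyond the usual scatter. The methoxy group also cannot be told apart from the methyl group here, given a 1.6-fold higher number from compound 2 to compound 4 (0.21 log units; within the scatter), so among these three groups only ethyl stands apart, with methyl and methoxy reading alike. Nothing in the available data explains why this swap changes the number.

Going by these compounds, it remains open whether ethoxy, which pairs the oxygen link of methoxy with the two-carbon length of ethyl, would behave like methoxy or like ethyl. On these data alone, a longer chain such as propyl, or an amine such as dimethylamino on the same carbonyl carbon, also remains untested in these compounds.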